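The compounds below may be only part of what the source reports. "The series", "measured", "known", "first", "only" and "open" are said of these compounds alone.

Compound 1 `COc1ccc(-c2cnc(NC(=O)c3ccccc3O)n2C)cc1` was tested in a toxicity assay on THP-1 cells (Homo sapiens) for inhibition (a higher number here means that more compound is tolerated, a lower number that less compound is tolerated), and gave only a limit, > 100000 nM. Compound 2 `Cn1c(-c2ccccc2Cl)cnc1NC(=O)c1ncc[nH]1` likewise reached only a limit in this assay, > 50000 nM. Compound 3 `COc1ccc(CNC(=O)NC(=O)c2ccc(F)cc2)cc1` also gave a limit in this assay, > 50000 nM. Going by the values given here, compound 1 thus stands at the limit of > 100000 nM in this assay, at which 1 of the 3 values shown sits, while the other two values sit at the limit of > 50000 nM in this assay, at which 2 of the 3 values shown sit; none of the three is a number, so no step between measured compounds can be drawn. The unmeasured compound 4 `COc1ccc(-c2cnc(NC(=O)c3cccc(C)c3)n2C)cc1` differs from compound 1 by 3-methylphenyl in place of 2-hydroxyphenyl on a carbonyl carbon. In this assay the expected change is a number no higher from compound 1 to compound 4 (the limit leaves the size open), none beyond the scatter. Compound 4 is estimated at 100000 nM, in a range from 40000 nM to 250000 nM, and most probably the assay will again report only a limit.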

Compound 4, half-maximal cytotoxic concentration: > 100000 nM
Compound 4 was reported as a limit; the forecaster's own chance of this, stated with the estimate: 80%; the middle value lies on the limit itself.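

Compound 1 and compound 4 both give only a limit in this assay, so the step between them cannot be read: the limit of > 100000 nM in this assay, at which 2 of the 4 values shown sit.

The compounds shown leave open at what concentration any of them stops being tolerated.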